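The source may report more compounds than this note shows. Statements on the series, on what has been measured and on what is new or still open speak of the compounds shown alone.

Working notes on the series.

Compound 1 `CCC(=O)[C@@H](C)c1oc([C@H](C)[C@@H]2O[C@](O)([C@@H](C)c3oc(CC)c(C)c(=O)c3C)[C@@H](C)[C@@H](O)[C@@H]2C)c(C)c(=O)c1C` is the cyclic hemiketal member of the set. In a functional assay on SK-MEL-28 cells (Homo sapiens) for inhibition, read by MTT assay, with a stated time of 72 h (on this read-out lower numbers stand for stronger inhibition and higher numbers for weaker inhibition), compound 1 gives > 100000 nM, which is a limit of the assay and not a number. Two open-chain relatives give numbers in this assay: compound 2 `CCC(=O)O[C@@H](/C(C)=C/[C@@H](C)c1oc(CC)c(C)c(=O)c1C)[C@H](C)[C@@H](OC(=O)CC(C)C)[C@@H](C)c1oc([C@@H](C)[C@H](CC)OC(C)=O)c(C)c(=O)c1C` gives 7000 nM, and compound 3 `CCC(=O)O[C@@H](/C(C)=C/[C@@H](C)c1oc(CC)c(C)c(=O)c1C)[C@H](C)[C@@H](OC(=O)CC(C)C)[C@@H](C)c1oc([C@@H](C)[C@@H](O)CC)c(C)c(=O)c1C` gives 25000 nM. Going by the values given here, the only single-point step with numbers on both sides is a 3.6-fold higher number from compound 2 to compound 3 (0.55 log units; beyond the scatter), and it concerns an ester-to-alcohol exchange far from the change considered here. On the numbers shown, compound 1 stands at the weak end of the set, sitting on the limit at which (the limit of > 100000 nM in this assay, at which 1 of the 3 values shown sits).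

The step now followed is from compound 1 to compound 4 `CCC(=O)[C@H](C)c1oc([C@H](C)[C@@H]2O[C@](O)([C@@H](C)c3oc(CC)c(C)c(=O)c3C)[C@@H](C)[C@@H](O)[C@@H]2C)c(C)c(=O)c1C`. The difference is the two compounds have the same atoms and bonds and differ only in configuration as drawn: 1 of 8 stereo elements differ; a stereocentre at a saturated chain carbon is drawn S in compound 1 and R in compound 4. Among the compounds with values here, no measured step in the set bears on an inversion of a single stereocentre, so no direction can be read from compound 2 or compound 3, and the starting point is itself a limit. Compound 4 is therefore expected to remain near the limit, with an expected step of a number no higher from compound 1 to compound 4 (the limit leaves the size open). The estimate for compound 4 in this assay is 100000 nM, within a range of 30000 nM to 300000 nM, with a real chance that only a limit is reported.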

Compound 4, half-maximal inhibitory concentration: > 100000 nM
Compound 4: only a limit was reported; the forecaster's own chance of this, stated with the estimate: 70%; the middle value sits exactly at the limit.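

In this assay no new step can be read between compound 1 and compound 4, as each gives only a limit and not a number: the limit of > 100000 nM in this assay, at which 2 of the 4 values shown sit. The compounds shown leave open whether the configuration at this saturated chain carbon affects inhibition at all, with the comparison resting on a single difference: the fact that compounds 1 and 4 differ only in the configuration as drawn.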